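A few compounds are considered here, and "the series" means these few. Any claim that something is new, unique, unknown or untested is made for them only; others in the source may bear on it.

Measured so far:
- compound 1, `Cc1ccc(C(CCN(C)C)NC(=O)C#Cc2ccccc2)cc1`: in a functional assay on NIH3T3 cells for agonist activity at Urotensin-2 receptor (Homo sapiens), with a stated time of 5 days (on this read-out lower numbers stand for an effect already at smaller amounts and higher numbers for an effect only at larger amounts of compound), compound 1 gives 3090 nM
- compound 2, `COc1ccc(CCC(=O)NC(CCN(C)C)c2ccc3ccccc3c2)cc1`: in this assay compound 2 gives 1410 nM

Compound 1 stands at the higher of these two numbers; compound 2 shows a lower number, and the gap between the two lies beyond the usual scatter. The two compounds differ in several places at once, so nothing can be read off about any single change from that pair alone.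

Compound 3, `Cc1ccc(C(CCN(C)C)NC(=O)CCc2ccccc2)cc1`, has not yet been measured. It differs from compound 1 in one place only: phenethyl in place of 2-phenylethynyl on a carbonyl carbon. The chain that joins the carbonyl carbon to the outer aromatic ring keeps its length and loses only its triple bond.

Among the measured compounds shown here, since no measured pair shows this change on its own, the size of the step is uncertain. Compound 2, which carries a saturated chain of the same kind, gives the lower number, but its other differences from compound 1 make it a weak guide. A small step towards a lower number, or none beyond the scatter, is expected, so that the step from compound 1 to compound 3 is estimated as a 1.5-fold lower number from compound 1 to compound 3 (0.19 log units; within the scatter). For compound 3 the value in this assay is estimated at 2000 nM, within a range from 600 nM to 6500 nM.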

Compound 3, half-maximal effective concentration: 4570 nM
Beside the measured number, compound 3's estimate is 2.3-fold (0.36 log units) below it; the measured number falls inside the stated range.
By their numbers in this assay, from the lowest: compound 2; then compounds 1 and 3 (each within the scatter of the next).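

Phenethyl in place of 2-phenylethynyl on a carbonyl carbon gives a 1.5-fold higher number from compound 1 to compound 3 (0.17 log units; within the scatter) in this assay. Among the compounds shown here, this is the first direct reading of this single change, and it shows that compound 1 and compound 3, whose groups each hold one aromatic ring of carbon and differ in that only the 2-phenylethynyl has a triple bond, cannot be told apart on this read-out, so the triple bond is not needed here for a number in this range. No measurement of any other property bears on this result, so the data offer no explanation for it.

Going by these compounds, what remains open is how far this position tolerates larger changes, for example a longer chain between the carbonyl carbon and the outer aromatic ring, or a carboxylic acid or an amine in place of that ring. Also open, on these data alone, is whether removing the triple bond would read the same way on a core other than that of compound 1, since a single pair of compounds cannot show whether this result holds more widely.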